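Moving the Trifluoromethyl Group to Another Ring Position

This account rests on a few compounds, and the source may have more. Where it says the series, first, only, none or still open, it means among the compounds named here.

Three compounds share one core and differ only in the aryl group carried by an amine nitrogen in a ring. Compound 1 `Nc1scc(CN2CCN(c3cccc(Cl)c3Cl)CC2)c1C(=O)c1ccc(Cl)cc1` gives -77% in a functional assay on CHO cells with adenosine receptor A1 (Homo sapiens) as the target, read by cAMP accumulation and immunoassay, with a stated time of 6 min, tested at 10 uM; a higher number here means a weaker effect of the compound at the concentration tested, a lower number a stronger effect. Compound 2 `Nc1scc(CN2CCN(c3ccc(Cl)cc3F)CC2)c1C(=O)c1ccc(Cl)cc1` gives -81% in this assay, and compound 3 `Nc1scc(CN2CCN(c3cccc(C(F)(F)F)c3)CC2)c1C(=O)c1ccc(Cl)cc1` gives -80%. Among these three numbers compound 3 stands second highest; its nearest neighbour is compound 2 and compound 1 lies furthest from it, yet both gaps stay within the scatter of repeated measurements, so the three compounds cannot be told apart on these values.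

Compound 4 `Nc1scc(CN2CCN(c3ccccc3C(F)(F)F)CC2)c1C(=O)c1ccc(Cl)cc1` has not yet been measured. It differs from compound 3 in one place: 2-(trifluoromethyl)phenyl in place of 3-(trifluoromethyl)phenyl on an amine nitrogen in a ring. The same atoms are present, only joined differently.

Every measured step bears on this change, since each swaps one aryl group on that nitrogen for another: a number 4 percentage points lower from compound 1 to compound 2 (within the scatter), a number 3 percentage points lower from compound 1 to compound 3 (within the scatter) and a number 1 percentage points higher from compound 2 to compound 3 (within the scatter). None of them moved the read-out beyond the scatter. The step of a number 1 percentage points higher from compound 3 to compound 4 (within the scatter) is therefore expected to stay within the scatter as well. Compound 4 is estimated at -79% in this assay, with a range from -92% to -62%.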

Compound 4, a percentage reported as activity, at one concentration (the size of the read-out at that concentration, not a potency): -60%
Beside the measured number, compound 4's estimate is 19 percentage points below it; measured number above the stated range.
By their numbers in this assay, from the lowest: compounds 2, 3 and 1 (each within the scatter of the next); then compound 4.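

Moving the trifluoromethyl group around the phenyl ring is the first change on this amine nitrogen to shift the read-out beyond the scatter, with a number 20 percentage points higher from compound 3 to compound 4 (beyond the scatter) in this assay, even though the two groups have the same atoms. The shift is not tied to compound 3 alone, as the other two compounds give a number 21 percentage points higher from compound 2 to compound 4 (beyond the scatter) and a number 17 percentage points higher from compound 1 to compound 4 (beyond the scatter), so a higher number, meaning a weaker effect at the concentration tested, sets compound 4 apart from all three earlier compounds. Compound 1 with 2,3-dichlorophenyl and compound 2 with 4-chloro-2-fluorophenyl also have a group numbered 2 on the phenyl ring, so that numbering alone does not go with the weaker effect; among these four compounds, only 2-(trifluoromethyl)phenyl does.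

Nothing available here explains why this one change moves the read-out while the others do not. As far as these compounds go, it also remains open whether the same weakening would appear with 4-(trifluoromethyl)phenyl, or with a methoxy group or a nitrile in place of the trifluoromethyl group in 2-(trifluoromethyl)phenyl.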